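A Fluoro Group on the Phenethyl Arm

The source may hold more compounds than are shown below. What is called first, only, known or untested is meant among the compounds shown, and "the series" means these compounds.

In a functional assay on THP-1 cells (Homo sapiens) for inhibition (a higher number here means a weaker inhibitor of growth, a lower number a stronger inhibitor of growth), compound 1 `Cc1noc(C)c1-c1ccc2c(c1)c(CCc1ccccc1)cn2CCCCCC(=O)NO` gives 15500 nM and compound 2 `Cc1noc(C)c1-c1ccc2c(c1)c(CCc1ccccc1)cn2CCCCCCC(=O)NO` gives 15500 nM so compound 2 stands level with compound 1. Compound 3 `Cc1noc(C)c1-c1ccc2c(c1)c(CCc1ccc(F)cc1)cn2CCCCCCC(=O)NO` differs from compound 2 by fluoro in place of hydrogen on an aromatic carbon as phenethyl becomes 2-(4-fluorophenyl)ethyl. Among the measured compounds shown here, the only measured step is no change at the digits printed from compound 1 to compound 2 (within the scatter) and it concerns the chain, so no measurement speaks directly to fluoro in place of hydrogen on an aromatic carbon. No shift beyond the scatter is therefore expected, and the expected step is a 1.0-fold lower number from compound 2 to compound 3 (0.01 log units; within the scatter) with no firm direction. Compound 3 is estimated at 15000 nM with an expected range from 7000 nM to 30000 nM in this read-out.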

Compound 3, concentration for 50% growth inhibition: 15500 nM
Compound 3: the middle estimate sits 1.0-fold (0.01 log units) below what was measured; the measured number falls inside the stated range.
By their numbers in this assay, from the lowest: compounds 1, 2 and 3 (each within the scatter of the next).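

In this assay, fluoro in place of hydrogen on an aromatic carbon, para to a large group, gives no change at the digits printed from compound 2 to compound 3 (within the scatter). Among the compounds shown here, this is the first reading on the phenethyl arm, since the earlier pair spoke only to the chain, and phenethyl and 2-(4-fluorophenyl)ethyl read alike here. No available evidence bears on this result. From the compounds shown here alone, whether methoxy, an amine or a carboxylic acid in that place would read the same stays open. So does whether a longer chain would move the number when it is paired with 2-(4-fluorophenyl)ethyl.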